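Triazene series: chloro for acetyl and lipophilicity

The source may report more compounds than this note shows. Statements on the series, on what has been measured and on what is new or still open speak of the compounds shown alone.

Measured so far:
compound 1 `CC(=O)c1ccccc1/N=N/N(C)C` — 2.19
compound 2 `CN(C)/N=N/c1ccccc1Cl` — 2.97
compound 3 `CC(=O)c1cccc(/N=N/N(C)C)c1` — 2.19

Compound 1 and compound 3 are built from the same atoms joined differently; the difference between the two cores is not broken down here. In a physicochemical assay for lipophilicity (on this read-out lower numbers stand for lower lipophilicity and higher numbers for higher lipophilicity), compound 3 stands level with compound 1 at the digits given, the two together being the lowest of the three numbers. The step of a number 0.78 log units higher from compound 1 to compound 2 (beyond the scatter) is made by chloro in place of acetyl on an aromatic carbon.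

Compound 4 `CN(C)/N=N/c1cccc(Cl)c1` is not yet measured; it arises from compound 3 by chloro in place of acetyl on an aromatic carbon. This is the same kind of change, but the chloro sits ortho to a group of 5 heavy atoms in compound 2 and meta to a group of 5 heavy atoms in compound 4. Because compound 3 gives 2.19, a step of the same size as the one already seen is expected, a number 0.78 log units higher from compound 3 to compound 4 (beyond the scatter). This rests on a number 0.78 log units higher from compound 1 to compound 2 (beyond the scatter) alone. Compound 4 is therefore estimated at 2.97, expected between 2.6 and 3.3.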

Compound 4, partition coefficient: 3.3
The estimate for compound 4 lay 0.33 log units below the measured number, within the range that was stated.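

In this assay, chloro in place of acetyl on an aromatic carbon gives a number 1.11 log units higher from compound 3 to compound 4 (beyond the scatter), the same direction as a number 0.78 log units higher from compound 1 to compound 2 (beyond the scatter), so the sign of the change carries between these two cores. The size does not carry unchanged: the step is large on the core of compound 3 and modest on the core of compound 1, and two pairs set no rule for any further core. Nothing shown bears on why the two sizes differ.

As far as these compounds go, whether an amine or a carboxylic acid in place of acetyl would follow the same direction on both cores remains open. Also open, from the compounds shown here alone, is whether a longer chain in place of acetyl would give steps that match between the cores.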